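The source may report more compounds than this note shows. Statements on the series, on what has been measured and on what is new or still open speak of the compounds shown alone.

Among the measured compounds shown here, compound 1 `C[C@@H](NC(=S)NCc1ccccc1)c1nc2ccccc2[nH]1` is a thiourea on the shared core; in a functional assay on DU-145 cells (Homo sapiens) for cytotoxicity, read by MTT assay (a higher number here means a weaker inhibitor, a lower number a stronger inhibitor), compound 1 gives 28700 nM, the lower of the two numbers measured so far. For the measured compounds named here, its mirror-image partner, compound 2 `C[C@H](NC(=S)NCc1ccccc1)c1nc2ccccc2[nH]1`, differs only in the configuration as drawn, and in this assay compound 2 gives 226000 nM; the step of a 7.9-fold higher number from compound 1 to compound 2 (0.90 log units; beyond the scatter) is the single measured change on record, and it is ascribed to the fact that compounds 1 and 2 differ only in the configuration as drawn.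

The compound now in question, compound 3 `C[C@@H](NC(=S)Nc1ccccc1)c1nc2ccccc2[nH]1`, keeps the configuration of compound 1 and changes the other end of the thiourea: phenyl in place of benzyl on an amide-type nitrogen. Going by the values given here, no measured step speaks to a change of this kind, since the only one available concerns configuration alone, so the expectation rests on compound 1 itself and is wide. Compound 3 is therefore expected to show a step of a 1.0-fold higher number from compound 1 to compound 3 (0.02 log units; within the scatter), that is, no change beyond the scatter. Compound 3 is estimated at 30000 nM, within the range 8000 nM to 120000 nM.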

Compound 3, half-maximal inhibitory concentration: 22100 nM
For compound 3 the middle estimate is 1.4-fold (0.13 log units) above the measured one, within the range that was stated.
By their numbers in this assay, from the lowest: compounds 3 and 1 (each within the scatter of the next); then compound 2.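

In this assay, the change at the far end of the thiourea gives a 1.3-fold lower number from compound 1 to compound 3 (0.11 log units; within the scatter), so benzyl and phenyl on this amide-type nitrogen are not told apart by this read-out while the configuration of compound 1 is held. The earlier compounds had shown only that the configuration as drawn moves the number beyond the scatter; this is the first measured change at this position, and it stays within the scatter. The one available explanation concerns configuration alone and has no bearing on this exchange of groups.

As far as these compounds go, whether a longer chain such as phenethyl, or a ring carrying an amine or a carboxylic acid, would leave the number as unchanged on this nitrogen remains open. So does whether the gap between mirror images seen with benzyl also holds with phenyl.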